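Shortening the Hydroxycarbamoyl Chain of Compound 2

The compounds below may be only part of what the source reports. "The series", "measured", "known", "first", "only" and "open" are said of these compounds alone.

Measured in a functional assay on HepG2 cells (Homo sapiens) for inhibition, read by MTT assay, with a stated time of 72 h; a lower number here means a stronger inhibitor, a higher number a weaker inhibitor:
Compound 1 `Nc1ncnc2c1c(-c1cnc3[nH]ccc3c1)nn2CC(=O)NO`: > 150000 nM (a limit)
Compound 2 `Nc1nc2cc(-c3nn(CCCC(=O)NO)c4ncnc(N)c34)ccc2o1`: > 50000 nM (a limit)

In this assay, compound 2 stands at > 50000 nM, which is a limit and not a number. Compound 1, which bears the (hydroxycarbamoyl)methyl chain, gives > 150000 nM, also a limit. Compound 3 `Nc1nc2cc(-c3nn(CC(=O)NO)c4ncnc(N)c34)ccc2o1` follows from compound 2 by hydroxycarbamoyl in place of 2-(hydroxycarbamoyl)ethyl on a saturated chain carbon bound to an aromatic nitrogen. No measured step sizes this change. With compound 1 at its limit of > 150000 nM, no shift beyond the scatter is expected in this assay. The expected step is a step that the limit leaves unreadable from compound 2 to compound 3. For compound 3 the estimated value is 80000 nM, within an expected range of 25000 nM to 200000 nM.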

Compound 3, half-maximal inhibitory concentration: > 150000 nM
Compound 3 was reported as a limit; the forecaster's own chance of this, stated with the estimate: 85%; middle value at least 1.8-fold (0.27 log units) away from the limit.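

For the compounds shown here, compound 2 and compound 3 are both reported only as limits in this assay, and no step between them can be read. The compounds shown leave open whether the change from 3-(hydroxycarbamoyl)propyl to (hydroxycarbamoyl)methyl moves the half-maximal inhibitory concentration at all.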